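Para substituent on the pendant aryl ring: methyl analogue

The compounds below may be only part of what the source reports. "The series", "measured", "known", "first", "only" and "open" are said of these compounds alone.

Two compounds of this series carry a measurement. Compound 1 `COc1ccc(-c2cc(C(=O)Nc3ccc(Oc4ccnc5[nH]ccc45)c(F)c3)ncn2)cc1` gives 2570 nM in a functional assay on PC-3 cells (Homo sapiens) for cytotoxicity, read by MTT assay, with a stated time of 72 h; on this read-out lower numbers stand for stronger inhibition and higher numbers for weaker inhibition. Compound 2 `O=C(Nc1ccc(Oc2ccnc3[nH]ccc23)c(F)c1)c1cc(-c2ccc(C(F)(F)F)cc2)ncn1` gives 4120 nM in this assay. Among the measured compounds shown here, the single step between them, a 1.6-fold higher number from compound 1 to compound 2 (0.20 log units; within the scatter), is the only one available and it does not exceed the scatter, so on these two numbers compound 2 cannot be told apart from compound 1.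

Compound 3 `Cc1ccc(-c2cc(C(=O)Nc3ccc(Oc4ccnc5[nH]ccc45)c(F)c3)ncn2)cc1` is unmeasured. It differs from compound 2 by methyl in place of trifluoromethyl on an aromatic carbon. For the measured compounds named here, the one step that bears on this position, a 1.6-fold higher number from compound 1 to compound 2 (0.20 log units; within the scatter), exchanged one small group for another on the same aromatic carbon without moving the number beyond the scatter. Nothing in the data separates methyl from either of those groups, so the expectation for this assay is a step of a 1.3-fold lower number from compound 2 to compound 3 (0.11 log units; within the scatter) from compound 2 to compound 3, that is none beyond the scatter.

Compound 3 is therefore estimated at 3200 nM in this assay, with a range of 1500 nM to 7000 nM.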

Compound 3, half-maximal inhibitory concentration: 24900 nM
Beside the measured number, compound 3's estimate is 7.8-fold (0.89 log units) below it, outside the stated range (above it).
By their numbers in this assay, from the lowest: compounds 1 and 2 (each within the scatter of the next); then compound 3.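

In this assay this aromatic carbon proves sensitive to the group it carries: methyl in place of trifluoromethyl gives a 6.0-fold higher number from compound 2 to compound 3 (0.78 log units; beyond the scatter) and methyl in place of methoxy gives a 9.7-fold higher number from compound 1 to compound 3 (0.99 log units; beyond the scatter) in the same direction. The earlier pair, which could not be told apart, therefore did not show that groups at this carbon are interchangeable, and compound 3 is the weakest of the three, with the 4-methylphenyl group the only one of the three aryl groups that separates from the others. The data shown offer no measurement that accounts for why methyl departs from methoxy and trifluoromethyl.

As far as these compounds go, it remains open whether the hydrogen analogue of the ring would sit with compound 3 or with compound 1 and compound 2, which would show whether methyl lowers the response or the other two groups raise it. Also open, from the compounds shown here alone, is how a chlorine atom, an amine, a carboxylic acid or a longer chain such as ethyl at this same carbon would fall relative to these three compounds.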